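A Fluorinated Phenyl Replaces a Furan on the Shared Core

The source may hold more compounds than are shown below. What is called first, only, known or untested is meant among the compounds shown, and "the series" means these compounds.

Of the compounds shown here, three built on one shared core have been tested in an assay on CHO cells for displacement of a labelled ligand from adenosine receptor A3 (Homo sapiens), read by scintillation counting, tested at 10 uM; a higher number here means more inhibition at the concentration tested (going by the name of the read-out), a lower number less inhibition. Compound 1 `CC(C)Cc1csc(N)c1C(=O)c1ccc(Cl)cc1` gives 1%. Compound 2 `Cc1c(Br)sc(N)c1C(=O)c1ccc(Cl)cc1` gives 1%, and compound 3 `CC(C)(C)Cc1c(-c2ccoc2)sc(N)c1C(=O)c1ccc(Cl)cc1` gives 1%. Compound 3 therefore stands level with compounds 1 and 2 at the digits shown; its reading lies within the scatter of both, so the three readings in this assay are level with one another.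

Compound 4 `CC(C)(C)Cc1c(-c2cccc(F)c2F)sc(N)c1C(=O)c1ccc(Cl)cc1` has not yet been measured. It differs from compound 3 in one place: 2,3-difluorophenyl in place of furan-3-yl on an aromatic carbon. The group that leaves carried one hydrogen-bond acceptor; the group that enters carries none, and it is larger by three heavy atoms.

Within the data shown here, no pair of measured compounds shows how a change at this position moves the reading, so the expectation rests on the three values alone, which all sit at the same low level. The expected step is a number 1 percentage points higher from compound 3 to compound 4 (within the scatter), judged to lie within the scatter rather than in any direction. Compound 4 is expected to give about 2%, with a range from -8% to 14%, because compound 3 gives 1% and the earlier changes on this core left the reading unchanged.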

Compound 4, a percentage reported as inhibition, at one concentration (the size of the read-out at that concentration, not a potency): 1%
The estimate for compound 4 lay 1 percentage points above the measured number, within the range that was stated.
By their numbers in this assay, from the lowest: compounds 1, 2, 3 and 4 (each within the scatter of the next).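

Among these compounds, this is the first pair on the shared core that differs in one place, so a change on the aromatic carbon next to the ring sulfur can now be read directly: in this assay, putting 2,3-difluorophenyl in place of furan-3-yl gives no change at the digits printed from compound 3 to compound 4 (within the scatter). The swap is not a small one, since a five-membered aromatic ring with a hydrogen-bond acceptor gives way to a larger six-membered aromatic ring of carbon only, yet compound 4 stays at 1% and so shows no sign of inhibition rising with this change. No measurement shown here offers an explanation for this outcome.

With both readings this low, a single pair cannot tell whether this position matters to the receptor or whether the shared core as a whole shows little inhibition at the concentration tested. Going by these compounds, it remains open whether an amine or a carboxylic acid on this carbon, or a longer chain in place of the neopentyl group, would move the reading at all.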